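Working notes on the step from compound 1 to compound 4

The source may hold more compounds than are shown below. What is called first, only, known or untested is meant among the compounds shown, and "the series" means these compounds.

Measured so far in a functional assay on cells (T-cell, Homo sapiens) for inhibition; on this read-out higher numbers stand for weaker inhibition and lower numbers for stronger inhibition:
- compound 1 `COc1ccc(-c2cnc3nc(N)nc(N4CCN(C(=O)COc5ccccc5)CC4)c3n2)cc1OC` gives 4 nM
- compound 2 `CCOc1nc(N)nc2ncc(-c3ccc(C(F)(F)F)cc3)nc12` gives 10000 nM
- compound 3 `COc1ccc(-c2cnc3nc(N)nc(NC4CCCC4)c3n2)cc1OC` gives 800 nM

Compound 1 stands at the lowest number of the three in this assay. Its nearest neighbour is compound 3, whose number is far higher and beyond the scatter; compound 2 lies furthest away, also beyond the scatter. Among the measured compounds shown here, none of the measured pairs differs in only one place, so no measured step is available to guide the next change.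

Compound 4 `COc1ccc(-c2cnc3nc(N)nc(N4CCN(c5ccccc5)CC4)c3n2)cc1OC` differs from compound 1 in one place: phenyl in place of (phenoxymethyl)carbonyl on an amine nitrogen in a ring. The group that leaves carries hydrogen-bond acceptors and a carbonyl; the group that enters carries neither. For the measured compounds named here, nothing among the measured compounds shows what this particular exchange does, so the expectation rests on compound 1 alone and on a cautious reading of the change. A modest step toward weaker inhibition is expected, a 3.0-fold higher number from compound 1 to compound 4 (0.48 log units; beyond the scatter), which may still fall within the scatter. Compound 4 is estimated to give about 12 nM in this assay, with a range from 3 nM to 60 nM.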

Compound 4, half-maximal inhibitory concentration: 400 nM
Beside the measured number, compound 4's estimate is 33-fold (1.52 log units) below it, and the stated range ends below it.
By their numbers in this assay, from the lowest: compound 1; then compounds 4 and 3 (each within the scatter of the next); then compound 2.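

In this assay, phenyl in place of (phenoxymethyl)carbonyl on the amine nitrogen in the ring gives a 100-fold higher number from compound 1 to compound 4 (2.00 log units; beyond the scatter). Among the compounds shown here, this is the first one-place step, and it shows that the number depends strongly on what this ring nitrogen carries. A six-membered aromatic ring of carbon only is present on both sides of the step, so that ring alone does not preserve the value of compound 1, 4 nM, and nothing measured here accounts for the size of the step.

The compounds shown leave open whether the carbonyl or the phenoxymethyl part carries the difference. An acetyl or a benzoyl group on this same nitrogen would separate the two.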